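This account rests on a few compounds, and the source may have more. Where it says the series, first, only, none or still open, it means among the compounds named here.

Measured so far in a functional assay on SW-620 cells (Homo sapiens) for cytotoxicity, read by MTT assay, with a stated time of 72 h (a lower number here means a stronger inhibitor, a higher number a weaker inhibitor), for the series:
- compound 1 `COc1cccc(/C=C2\CCC/C(=C\c3cccc(OC)c3OC)C2=O)c1` gives 7000 nM
- compound 2 `COc1ccc(/C=C2\CCC/C(=C\c3cccc(OC)c3OC)C2=O)cc1` gives 13600 nM
- compound 3 `COc1cccc(/C=C2\CCC/C(=C\c3ccc(Cl)c(Cl)c3)C2=O)c1OC` gives 10000 nM

Compound 2 does not separate from the other two compounds. The steps of a 1.9-fold higher number from compound 1 to compound 2 (0.29 log units; within the scatter) and a 1.4-fold lower number from compound 2 to compound 3 (0.13 log units; within the scatter) both stay within the scatter, so the three values give no ranking.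

The next compound is compound 4 `COc1ccc(/C=C2\CCC/C(=C\c3cccc(OC)c3OC)C2=O)cc1OC`, which differs from compound 2 by methoxy in place of hydrogen on an aromatic carbon in one place. Methoxy stands in place of hydrogen on an aromatic carbon, ortho to a methoxy group and meta to a large group.

Within the data shown here, no measured pair shows this exact change, so the evidence is indirect. The nearest guides are the three steps that alter the same substituted phenyl group while the rest of the molecule stays fixed. These are a 1.9-fold higher number from compound 1 to compound 2 (0.29 log units; within the scatter) and a 1.4-fold higher number from compound 1 to compound 3 (0.15 log units; within the scatter) and a 1.4-fold lower number from compound 2 to compound 3 (0.13 log units; within the scatter) and each remains within the scatter. On that basis no step beyond the scatter is expected in this assay and no firm direction can be assigned.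

The expected change is a 1.5-fold lower number from compound 2 to compound 4 (0.18 log units; within the scatter) and it is not expected to exceed the scatter. Compound 4 is estimated at 9000 nM with an expected range from 4000 nM to 20000 nM in this assay.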

Compound 4, half-maximal inhibitory concentration: 6400 nM
Compound 4: the middle estimate sits 1.4-fold (0.15 log units) above what was measured; measured number inside the range.
By their numbers in this assay, from the lowest: compounds 4, 1, 3 and 2 (each within the scatter of the next, the first and the last beyond it).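

In this assay, among these compounds, methoxy in place of hydrogen on an aromatic carbon, ortho to a methoxy group and meta to a large group, gives a 2.1-fold lower number from compound 2 to compound 4 (0.33 log units; beyond the scatter), the only step so far to pass the scatter, and only modestly. Compound 4 can also be read from compound 1, and the same entering group then gives a 1.1-fold lower number from compound 1 to compound 4 (0.04 log units; within the scatter), so this change separates compound 4 from compound 2 but not from compound 1, and the series still has no clear order beyond that single pair. Nothing measured on these compounds accounts for the two readings differing.

Still open, on these data alone, is whether the step from compound 2 to compound 4 holds up on repeat measurement, given how close it sits to the scatter, and whether it carries over when the other phenyl group changes, for instance with the 3,4-dichlorophenyl group of compound 3 kept fixed. Also open, as far as these compounds go, is whether methoxy itself matters here, which a hydroxyl, an ethoxy or a dimethylamino group on the same aromatic carbon would help to settle.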